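This account rests on a few compounds, and the source may have more. Where it says the series, first, only, none or still open, it means among the compounds named here.

Compound 1 `CSc1nc(NCCCNc2ccnc3cc(Cl)ccc23)c(C#N)c(-c2ccccc2)n1`: 20000 nM
Compound 2 `CSc1nc(-c2ccccc2)c(C#N)c(N2CCN(c3ccnc4cc(Cl)ccc34)CC2)n1`: >= 100000 nM
Compound 3 `CSc1nc(NCCCCNc2ccnc3cc(Cl)ccc23)c(C#N)c(-c2cccc([N+](=O)[O-])c2)n1`: >= 4000 nM

In an ADME assay on HEL cells (Homo sapiens) for cytotoxicity, read by microscopy (on this read-out lower numbers stand for higher toxicity in this test and higher numbers for lower toxicity in this test), compound 1 gives 20000 nM. For compound 2 the value >= 100000 nM is a limit of the assay and not a number, as recorded in the limit of >= 100000 nM in this assay, at which 1 of the 3 values shown sits. For compound 3 likewise the value >= 4000 nM is a limit, as recorded in the limit of >= 4000 nM in this assay, at which 1 of the 3 values shown sits, so compound 3 stands on no fixed number among the three. Compound 4 `COc1ccc(-c2nc(SC)nc(NCCCCNc3ccnc4cc(Cl)ccc34)c2C#N)cc1OC` differs from compound 3 in one place: 3,4-dimethoxyphenyl in place of 3-nitrophenyl on an aromatic carbon. Among the compounds with values here, with compound 3 known only as a limit, no measured step sets a scale for this change, and no shift beyond the scatter is expected in this assay. The step is expected to be a step that the limit leaves unreadable from compound 3 to compound 4. Compound 4 is expected to give 20000 nM, within 4000 nM to 100000 nM.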

Compound 4, minimum cytotoxic concentration: >= 100000 nM
Compound 4 ended at the assay's limit (the forecaster's own chance of this, stated with the estimate: 60%); middle value at least 5.0-fold (0.69 log units) away from the limit.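

Compound 3 and compound 4 are both known only as limits in this assay, so the step between them cannot be read. The compounds shown leave open how far 3,4-dimethoxyphenyl and 3-nitrophenyl differ on this read-out.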